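The source may hold more compounds than are shown below. What is called first, only, known or untested is meant among the compounds shown, and "the series" means these compounds.

Measured compounds:
- compound 1, `CC(=O)Nc1ccc(-c2nc3cc(C(F)(F)F)ccc3[nH]2)cc1`: 50000 nM
- compound 2, `O=C(CN1CCCCC1)Nc1ccc(-c2nc3ccccc3[nH]2)cc1`: > 100000 nM

In an ADME assay on Vero cells (Chlorocebus sabaeus) for cytotoxicity (a lower number here means that less compound is tolerated, a higher number that more compound is tolerated), compound 1 gives a number, 50000 nM. Compound 2 gives only a limit in this assay, > 100000 nM, so its standing is known only as the limit of > 100000 nM in this assay, at which 1 of the 2 values shown sits, and not as a point; of the two compounds shown it is the one that sits at the limit.

Compound 3, `O=C(CN1CCCCC1)Nc1ccc(-c2nc3cc(C(F)(F)F)ccc3[nH]2)cc1`, is the unmeasured member. It differs from compound 2 in one place: trifluoromethyl in place of hydrogen on an aromatic carbon. For the measured compounds named here, the same trifluoromethyl group is already present in compound 1, which sits at a number rather than a limit, and no step between two measured compounds isolates this change on its own.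

For this assay the step from compound 2 to compound 3 is expected to be small, an at least 1.2-fold lower number from compound 2 to compound 3 (0.09 log units; that floor lies within the scatter), either direction, with nothing beyond the usual scatter anticipated. Compound 3 is therefore estimated at 80000 nM, within 30000 nM to 200000 nM, and a limit-only read-out is considered quite possible.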

Compound 3, half-maximal cytotoxic concentration: 31000 nM
For compound 3 the middle estimate is 2.6-fold (0.41 log units) above the measured one, within the range that was stated.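

In this assay, for the compounds shown here, trifluoromethyl in place of hydrogen on an aromatic carbon gives an at least 3.2-fold lower number from compound 2 to compound 3 (0.50 log units; beyond the scatter), the first reading of this change on its own and one that lies beyond the scatter. With trifluoromethyl in place, piperidin-1-yl in place of hydrogen on a saturated chain carbon bound to a carbonyl carbon gives a 1.6-fold lower number from compound 1 to compound 3 (0.21 log units; within the scatter), which stays within the scatter. The first step is only a floor, since compound 2 is known only as a limit: the limit of > 100000 nM in this assay, at which 1 of the 3 values shown sits.

Going by these compounds, the full size of the trifluoromethyl step remains open, and it rests on a single pair of compounds. Also open, on these data alone, is whether chlorine or a nitrile at this carbon would give a similar step, and whether morpholine in place of piperidin-1-yl would leave the read-out within the scatter.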